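Phenethyl for furan-2-yl on a benzamido analogue

A few compounds are considered here, and "the series" means these few. Any claim that something is new, unique, unknown or untested is made for them only; others in the source may bear on it.

Measured so far in a functional assay on SK-MEL-2 cells (Homo sapiens) for cytotoxicity, read by sulforhodamine B assay, with a stated time of 2 days, tested at 100 uM; a higher number here means more inhibition at the concentration tested (going by the name of the read-out), a lower number less inhibition:
compound 1, `O=C(Nn1c(-c2cccc([N+](=O)[O-])c2)nc2c(-c3ccco3)n[nH]c2c1=O)c1cccnc1`, gives 19.2%
compound 2, `O=C(Nn1c(-c2cccc([N+](=O)[O-])c2)nc2c(CCc3ccccc3)n[nH]c2c1=O)c1cccnc1`, gives 28.5%
compound 3, `O=C(Nn1c(-c2cccc([N+](=O)[O-])c2)nc2c(-c3ccco3)n[nH]c2c1=O)c1ccccc1`, gives 23%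

Compound 4, `O=C(Nn1c(-c2cccc([N+](=O)[O-])c2)nc2c(CCc3ccccc3)n[nH]c2c1=O)c1ccccc1`, has not yet been measured. Compounds 1 and 2 differ in one place, (phenethyl in place of furan-2-yl on an aromatic carbon), and the step in this assay is a number 9.3 percentage points higher from compound 1 to compound 2 (within the scatter), so it lies within the scatter. Compound 3 stands beside compound 1 through a change at a different place, (phenyl in place of pyridin-3-yl on a carbonyl carbon), and that step in this assay is a number 3.8 percentage points higher from compound 1 to compound 3 (within the scatter), again within the scatter. Among the measured compounds shown here, compounds 2 and 3 have no direct step between them; their two values simply lie within the scatter of each other.

Compound 4 arises from compound 3 by the same change that turns compound 1 into compound 2: phenethyl in place of furan-2-yl on an aromatic carbon. The two place descriptions agree word for word, so this is the same change on a core that differs only in the benzoyl group in place of the pyridin-3-yl carbonyl. From compound 3 to compound 4 a step of a number 8 percentage points higher from compound 3 to compound 4 (within the scatter) in this assay is expected, resting on the earlier step of a number 9.3 percentage points higher from compound 1 to compound 2 (within the scatter). Compound 4 is therefore estimated at 31% in this assay, with a plausible range from 16% to 46%.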

Compound 4, a percentage reported as inhibition, at one concentration (the size of the read-out at that concentration, not a potency): 92%
Beside the measured number, compound 4's estimate is 61 percentage points below it; the whole stated range lies below it.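

In this assay, phenethyl in place of furan-2-yl gives a number 69 percentage points higher from compound 3 to compound 4 (beyond the scatter), and this step does not match the one seen on the core of compound 1: the same change on two cores in this assay, a number 9.3 percentage points higher (within the scatter) from compound 1 to compound 2 and a number 69 percentage points higher (beyond the scatter) from compound 3 to compound 4, 59.7 percentage points apart, beyond the scatter of two such steps

Phenyl in place of pyridin-3-yl gives a number 63.5 percentage points higher from compound 2 to compound 4 (beyond the scatter), and this too departs from its earlier counterpart: the same change on two cores in this assay, a number 3.8 percentage points higher (within the scatter) from compound 1 to compound 3 and a number 63.5 percentage points higher (beyond the scatter) from compound 2 to compound 4, 59.7 percentage points apart, beyond the scatter of two such steps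

Both lines rest on the same four compounds and so describe one finding: neither change carries its size from one core to the other here, and the large value appears only in compound 4, which holds both phenethyl and phenyl, though this does not show why the two changes combine in this way or how far the finding extends beyond these compounds.

The compounds shown leave open whether a benzyl group or a longer phenylpropyl chain in place of phenethyl would also give a high value. They also leave open whether a chlorophenyl or thiophene-2-yl carbonyl in place of the benzoyl group would do the same.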